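Hydroxy for Trifluoromethyl on the Amine-Bearing Ring

The source may report more compounds than this note shows. Statements on the series, on what has been measured and on what is new or still open speak of the compounds shown alone.

Of the compounds shown here, three have been tested in a functional assay on HT-29 cells (Homo sapiens) for antiproliferative activity, read by MTT assay, with a stated time of 48 h; a higher number here means a weaker inhibitor, a lower number a stronger inhibitor. Compound 1 `O=C(/C=C\Nc1ccc(O)cc1)c1cn(-c2ccccc2)nc1-c1ccc(F)cc1` gives 1900 nM. Compound 2 `COc1ccc(-c2nn(-c3ccccc3)cc2C(=O)/C=C\Nc2ccc(Cl)cc2)cc1` gives 4760 nM, and compound 3 `COc1ccc(-c2nn(-c3ccccc3)cc2C(=O)/C=C\Nc2ccc(C(F)(F)F)cc2)cc1` gives 9870 nM. Compound 3 thus stands at the highest number of the three, the weakest inhibitor of the set: the nearest number belongs to compound 2, the furthest to compound 1.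

Compound 4 `COc1ccc(-c2nn(-c3ccccc3)cc2C(=O)/C=C\Nc2ccc(O)cc2)cc1` has not yet been measured. It differs from compound 3 in one place: hydroxy in place of trifluoromethyl on an aromatic carbon. Among the measured steps, only one touches this position, a 2.1-fold higher number from compound 2 to compound 3 (0.32 log units; beyond the scatter), a modest change. Among the compounds with values here, no measured pair sets hydroxy directly against trifluoromethyl. Compound 1 carries the hydroxy on the same ring, but it also differs from compound 4 in the group on the other aromatic ring, so its value can only hint that a hydroxy at this position goes with a lower number than the two larger groups.

On that basis, compound 4 is expected to give a lower number than compound 3, by a step of about a 3.5-fold lower number from compound 3 to compound 4 (0.55 log units; beyond the scatter). Compound 4 is estimated at 2800 nM, with a likely range from 1000 nM to 8000 nM.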

Compound 4, half-maximal inhibitory concentration: 2460 nM
Compound 4: middle estimate off by 1.1-fold (0.06 log units), on the high side; the measured number falls inside the stated range.
By their numbers in this assay, from the lowest: compounds 1, 4 and 2 (each within the scatter of the next, the first and the last beyond it); then compound 3.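

The direct step in this assay gives a 4.0-fold lower number from compound 3 to compound 4 (0.60 log units; beyond the scatter) when hydroxy replaces trifluoromethyl, which sets these two groups against each other on one shared core and shows that the choice of group at this position matters. Hydroxy in place of chloro gives a 1.9-fold lower number from compound 2 to compound 4 (0.29 log units; within the scatter) and so cannot be told apart from chloro here, which means that among these three groups only trifluoromethyl stands clear of both of the others on this core. Methoxy in place of fluoro on the other aromatic ring gives a 1.3-fold higher number from compound 1 to compound 4 (0.11 log units; within the scatter) with the hydroxy held constant, so with this group on the amine-bearing ring, that second change leaves no difference that can be read beyond the scatter.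

The compounds shown leave open how an amine or a carboxylic acid at this position would compare with hydroxy and chloro, and whether the gap between hydroxy and trifluoromethyl would hold with fluoro on the other ring. Nothing given here explains why the numbers follow this order.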